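A few compounds are considered here, and "the series" means these few. Any claim that something is new, unique, unknown or untested is made for them only; others in the source may bear on it.

Compound 1 `CC1=CC[C@@H]([C@@](C)(O)CCCC(C)(C)NC(=S)NN)CC1` stands second highest of the three numbers in a functional assay on UACC-62 cells (Homo sapiens) for cytotoxicity, read by sulforhodamine B assay; a higher number here means a weaker inhibitor of growth, a lower number a stronger inhibitor of growth: compound 1 gives 18500 nM, compound 2 `CC1=CC[C@@H]([C@@](C)(O)CCCC(C)(C)NC(=S)N/N=C\c2ccc([N+](=O)[O-])cc2)CC1` gives 20800 nM, and compound 3 `CC1=CC[C@@H]([C@@](C)(O)CCCC(C)(C)NC(=S)N/N=C\c2cccc(Cl)c2)CC1` gives 7810 nM. Compound 4 `CC1=CC[C@@H]([C@@](C)(O)CCCC(C)(C)NC(=S)N/N=C(/C)c2ccccc2)CC1` carries a group of 9 heavy atoms (8 carbon, 1 nitrogen; one six-membered aromatic ring of carbon only) in place of one nitrogen atom, on an amide-type nitrogen. The step that bears on it most directly is a 2.4-fold lower number from compound 1 to compound 3 (0.37 log units; beyond the scatter), where a group of comparable size entered at the same amide-type nitrogen. The step of a 2.7-fold lower number from compound 2 to compound 3 (0.43 log units; beyond the scatter) shows that the ring substituent alone can move the number by a similar amount, so the unsubstituted ring of compound 4 need not match compound 3. A modest step towards a lower number in this assay is therefore expected, a 1.9-fold lower number from compound 1 to compound 4 (0.27 log units; within the scatter). Compound 4 is expected to give 10000 nM, with a range from 5000 nM to 22000 nM.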

Compound 4, concentration for 50% growth inhibition: 22400 nM
Compound 4: the middle estimate sits 2.2-fold (0.35 log units) below what was measured, and the stated range ends below it.
By their numbers in this assay, from the lowest: compound 3; then compounds 1, 2 and 4 (each within the scatter of the next).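

In this assay, an aromatic ring carried on the amide-type nitrogen does not by itself lower the number: the change gives (a 1.2-fold higher number from compound 1 to compound 4 (0.08 log units; within the scatter)), which stays within the scatter. The detail of the entering group does count, since the other step gives (a 2.9-fold higher number from compound 3 to compound 4 (0.46 log units; beyond the scatter)), beyond the scatter. No measurement shown explains this difference.

Still open, on these data alone, is whether the chlorine or the methyl on the carbon with a double bond to nitrogen accounts for that gap, as these two changes occur together. A 3-methoxyphenyl or pyridine ring at this place also remains untested among the compounds shown.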